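Amide to urea on a shared pyrazole-bearing core

The compounds below may be only part of what the source reports. "The series", "measured", "known", "first", "only" and "open" are said of these compounds alone.

Measured compounds:
compound 1, `COc1cc(-c2nn(-c3cccc(NC(=O)c4ccc(Cl)c(C(F)(F)F)c4)c3)cc2-c2ccncc2)ccc1Cl`: > 32500 nM
compound 2, `O=C(Nc1cccc(-n2cc(-c3ccncc3)c(-c3ccc(Cl)c(O)c3)n2)c1)Nc1cc(C(F)(F)F)cc(C(F)(F)F)c1`: 1810 nM

Compound 1 carries an amide of 4-chloro-3-(trifluoromethyl)phenyl on its core. Within the data shown here, in a functional assay on M14 cells (Homo sapiens) for inhibition, read by sulforhodamine B assay, with a stated time of 48 h (on this read-out higher numbers stand for weaker inhibition of growth and lower numbers for stronger inhibition of growth), compound 1 gives only a limit, > 32500 nM, so its place among the measured numbers is an edge rather than a point; it is the one value that sits at the limit of > 32500 nM in this assay, at which 1 of the 2 values shown sits. Compound 2 is a urea on a related but not identical core, and in this assay compound 2 gives 1810 nM. Among the measured compounds shown here, the two compounds differ in more than one place, so what they show is only that one is a number and the other a limit.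

Compound 3, `COc1cc(-c2nn(-c3cccc(NC(=O)Nc4cccc(C(F)(F)F)c4)c3)cc2-c2ccncc2)ccc1Cl`, is not yet measured. It differs from compound 1 in a single place: (3-(trifluoromethyl)phenyl)amino in place of 4-chloro-3-(trifluoromethyl)phenyl on a carbonyl carbon. Compound 3 therefore shares the urea linkage of compound 2 while keeping the core of compound 1. For the measured compounds named here, since compound 1 sits at a limit, a step in this assay toward stronger inhibition is expected, moving from the limit into the measurable range, though no measured step supports its size. Compound 3 is expected to give 8000 nM, within 2000 nM to 32500 nM, which would mean a step of an at least 4.0-fold lower number from compound 1 to compound 3 (0.60 log units; beyond the scatter).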

Compound 3, concentration for total growth inhibition: 1870 nM
The estimate for compound 3 lay 4.3-fold (0.63 log units) above the measured number; the measured number lies below the stated range.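

On the core of compound 1, putting (3-(trifluoromethyl)phenyl)amino in place of 4-chloro-3-(trifluoromethyl)phenyl on a carbonyl carbon brings an at least 17-fold lower number from compound 1 to compound 3 (1.24 log units; beyond the scatter) in this assay, and this is the only change in a single place among the compounds shown. In this assay compound 1 gives > 32500 nM, which is a limit of the assay and not a number. The full size of the step therefore cannot be read, because one of its two ends is such a limit: the limit of > 32500 nM in this assay, at which 1 of the 3 values shown sits.

The change adds a nitrogen with its hydrogen-bond donor and removes the chlorine in a single exchange, and the compounds shown do not separate these two differences. From the compounds shown here alone, it remains open whether (4-chloro-3-(trifluoromethyl)phenyl)amino on the same carbonyl carbon would give a similar value, and whether a methyl group or a carboxylic acid in place of the trifluoromethyl group would preserve the inhibition of growth seen with compound 3.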